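Aryl urea series: the step from iodo to ortho-methyl

The compounds below may be only part of what the source reports. "The series", "measured", "known", "first", "only" and "open" are said of these compounds alone.

Measured compounds, all in a functional assay on CRL2813 cells (Homo sapiens) for cytotoxicity, read by sulforhodamine B assay, with a stated time of 5 days; on this read-out higher numbers stand for weaker inhibition and lower numbers for stronger inhibition:
- compound 1, `Cc1ccc(NC(=O)N[C@H]2CC[C@H](Oc3ccc(F)cc3)CC2)cc1`: > 20000 nM, a limit of the assay rather than a number
- compound 2, `O=C(Nc1cccc([N+](=O)[O-])c1)N[C@H]1CC[C@H](Oc2ccc(F)cc2)CC1`: 6700 nM
- compound 3, `O=C(Nc1cccc(I)c1)N[C@H]1CC[C@H](Oc2ccc(F)cc2)CC1`: 5200 nM

Compound 3 gives the lower of the two numbers, and compound 2 sits close to it, a 1.3-fold lower number from compound 2 to compound 3 (0.11 log units; within the scatter). Compound 1 gives only a limit (the limit of > 20000 nM in this assay, at which 1 of the 3 values shown sits). The two steps from that limit, an at least 2.9-fold lower number from compound 1 to compound 2 (0.47 log units; beyond the scatter) and an at least 3.8-fold lower number from compound 1 to compound 3 (0.58 log units; beyond the scatter), show that swapping the 4-methylphenyl for either of the 3-substituted phenyls moves the number down.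

Compound 4, `Cc1ccccc1NC(=O)N[C@H]1CC[C@H](Oc2ccc(F)cc2)CC1`, is not yet measured. The change from compound 3 is 2-methylphenyl in place of 3-iodophenyl on an amide-type nitrogen. Among the measured compounds shown here, no measured pair has the same change, but compound 1, the only methylphenyl in the set, gives a limit, whereas the iodophenyl of compound 3 gives a number; the methyl of compound 4 sits at a different position from that of compound 1, so the comparison is indirect. A weakening step is expected, a 2.9-fold higher number from compound 3 to compound 4 (0.46 log units; beyond the scatter), with a real chance that only a limit is reported. Compound 4 is estimated at 15000 nM, within a range of 5000 nM to 40000 nM.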

Compound 4, half-maximal inhibitory concentration: > 20000 nM
Compound 4: no number, only a limit; the forecaster's own chance of this, stated with the estimate: 40%; middle value at least 1.3-fold (0.12 log units) from the limit.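

Compound 4 gives a limit and not a number, so moving the methyl to the 2-methylphenyl does not bring a measurable value: the set now reads the limit of > 20000 nM in this assay, at which 2 of the 4 values shown sit.

Against the two compounds with numbers, the 2-methylphenyl gives an at least 3.8-fold higher number from compound 3 to compound 4 (0.58 log units; beyond the scatter) and an at least 2.9-fold higher number from compound 2 to compound 4 (0.47 log units; beyond the scatter). Among the four compounds shown, the two methylphenyl ureas stop at the limit, while the 3-iodophenyl and 3-nitrophenyl ureas give numbers.

The step between the two methylphenyl compounds cannot be read, as both values are limits, so any difference between the 2-methylphenyl and the 4-methylphenyl stays unresolved. Open too, on these data alone, is whether the 3-position or the group on it carries the change, a question that 3-methylphenyl or 3-aminophenyl on the same amide-type nitrogen would address.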